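The source may hold more compounds than are shown below. What is called first, only, known or untested is meant among the compounds shown, and "the series" means these compounds.

Measured in a functional assay on NCI/ADR cells (Homo sapiens) for cytotoxicity, read by sulforhodamine B assay; a lower number here means a stronger inhibitor of growth, a higher number a weaker inhibitor of growth:
- compound 1 `CC1=CC[C@@H]([C@@](C)(O)CCCC(C)(C)NC(=S)NN)CC1`: 29000 nM
- compound 2 `CC1=CC[C@@H]([C@@](C)(O)CCCC(C)(C)NC(=S)N/N=C\c2ccc(C)cc2)CC1`: 30500 nM
- compound 3 `CC1=CC[C@@H]([C@@](C)(O)CCCC(C)(C)NC(=S)N/N=C\c2ccc(O)cc2)CC1`: 6070 nM

Compound 2 shares the upper end of these numbers. The measured steps show a 1.1-fold higher number from compound 1 to compound 2 (0.02 log units; within the scatter) and a 5.0-fold lower number from compound 2 to compound 3 (0.70 log units; beyond the scatter).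

Next in the series is compound 4 `CC1=CC[C@@H]([C@@](C)(O)CCCC(C)(C)NC(=S)N/N=C\c2ccccc2Cl)CC1`. The change is 2-chlorophenyl in place of 4-methylphenyl on a carbon with a double bond to nitrogen.

Among the measured compounds shown here, only one measured step alters a substituent on the aromatic ring alone, namely a 5.0-fold lower number from compound 2 to compound 3 (0.70 log units; beyond the scatter), and it is modest. The step of a 1.1-fold higher number from compound 1 to compound 2 (0.02 log units; within the scatter) shows that adding the 4-methylphenyl arm moved nothing, whereas the hydroxy-bearing arm gave a 4.8-fold lower number from compound 1 to compound 3 (0.68 log units; beyond the scatter). For the measured compounds named here, no measured compound carries 2-chlorophenyl, and with no hydroxy in the entering group, the modest step offers only a weak guide.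

In this assay, no step beyond the scatter is therefore expected, with a slight lean to a lower number. The expected step is a 1.5-fold lower number from compound 2 to compound 4 (0.18 log units; within the scatter).

Compound 4 is estimated at 20000 nM, with an expected range of 6500 nM to 50000 nM.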

Compound 4, concentration for total growth inhibition: > 100000 nM
Compound 4: a limit, no number; the forecaster's own chance of this, stated with the estimate: 8%; middle value at least 5.0-fold (0.69 log units) away from the limit.
By their numbers in this assay, from the lowest: compound 3; then compounds 1 and 2 (each within the scatter of the next). At a limit, above all of these: compound 4.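

In this assay compound 4 gives > 100000 nM, which is a limit of the assay and not a number. The arm on the carbon with a double bond to nitrogen can therefore move the read-out upward as well as downward, with an at least 3.2-fold higher number from compound 2 to compound 4 (0.51 log units; beyond the scatter) and an at least 16-fold higher number from compound 3 to compound 4 (1.21 log units; beyond the scatter). An arm without hydroxy is also not always silent: 4-methylphenyl left the number within the scatter of the core of compound 1, whereas 2-chlorophenyl gives an at least 3.4-fold higher number from compound 1 to compound 4 (0.53 log units; beyond the scatter).

The change from 4-methylphenyl to 2-chlorophenyl alters both the substituent and its place on the ring, so the compounds shown do not separate chlorine from its position. From the compounds shown here alone, how an arm carrying an amine or a carboxylic acid would read in this assay also remains open.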